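Capping the Amine: From Compound 1 to Compound 3

This account rests on a few compounds, and the source may have more. Where it says the series, first, only, none or still open, it means among the compounds named here.

Compound 1, `NC1CCN(c2ccc3cc(NC(=O)CCc4ccc(C(F)(F)F)cc4)ccc3n2)C1`, gives 200 nM in a functional assay on HEK293 cells for activation of melanin-concentrating hormone receptor 1 (Rattus norvegicus), read by inositol phosphate accumulation; a higher number here means that more compound is needed for the effect, a lower number that less compound is needed.
Compound 2, `O=C(CCc1ccc(C(F)(F)F)cc1)Nc1ccc2nc(N3CC4CC3CN4)ccc2c1`, gives 490 nM in this assay.

Compound 1 holds the lowest of the two numbers. Going by the values given here, the one measured step is a 2.5-fold higher number from compound 1 to compound 2 (0.39 log units; beyond the scatter). Compound 3, `CC(=O)NC1CCN(c2ccc3cc(NC(=O)CCc4ccc(C(F)(F)F)cc4)ccc3n2)C1`, differs from compound 1 by acetyl in place of hydrogen on an amine nitrogen. Among the compounds with values here, no measured step concerns an acetyl on that nitrogen, and the step to compound 2 alters the ring, not its nitrogen, so it gives only a loose guide. The number is nonetheless expected to rise beyond the scatter. Compound 3 is therefore expected at 1200 nM, with a range from 250 nM to 6000 nM. The expected step is a 6.0-fold higher number from compound 1 to compound 3 (0.78 log units; beyond the scatter).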

Compound 3, half-maximal effective concentration: 440 nM
For compound 3 the middle estimate is 2.7-fold (0.44 log units) above the measured one; measured number inside the range.
By their numbers in this assay, from the lowest: compound 1; then compounds 3 and 2 (each within the scatter of the next).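

Acetyl on this amine nitrogen gives a 2.2-fold higher number from compound 1 to compound 3 (0.34 log units; beyond the scatter) in this assay and so carries a modest cost, which shows that the nitrogen can bear this group and compound 3 still gives a measurable effect. The 3-acetamidopyrrolidin-1-yl group and the two-ring group of compound 2 are level, with a 1.1-fold lower number from compound 2 to compound 3 (0.05 log units; within the scatter) showing that these differently built groups cannot be told apart here. No measurement at hand offers an explanation for either step. From the compounds shown here alone, whether a methyl group, which would leave the nitrogen an amine, or a larger benzoyl group would bring the number closer to that of compound 1 remains open.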